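The source may hold more compounds than are shown below. What is called first, only, known or untested is meant among the compounds shown, and "the series" means these compounds.

Measured so far:
Compound 1 (`COc1cc(/C=C\c2ccc(C(C)(C)C)cc2)cc(OC)c1OC`): 2.1 uM
Compound 2 (`CCOc1ccc(/C=C/c2cc(OC)c(OC)c(OC)c2)cc1`): 1.17 uM

Both compounds were tested in a functional assay on SK-MEL-5 cells (Homo sapiens) for cytotoxicity; a lower number here means that less compound is needed, a higher number that more compound is needed for the effect. Among the compounds with values here, compound 1 has the higher of only two numbers, but the gap to compound 2 lies within the usual scatter, so the two cannot be told apart on this read-out.

Compound 3 (`CCCOc1ccc(/C=C\c2cc(OC)c(OC)c(OC)c2)cc1`) has not yet been measured. Compared with compound 1, it carries propoxy in place of tert-butyl on an aromatic carbon, para to a large group (propoxy in place of tert-butyl on an aromatic carbon). Within the data shown here, no measured pair isolates this change, so the data give no direct size for such a step. Among the measured compounds shown here, the only guide is the narrow spread of the two known values, with compound 1 at 2.1 uM and compound 2 at 1.17 uM. A modest move towards a lower number is expected, possibly no larger than the scatter. The expected change is a 2.3-fold lower number from compound 1 to compound 3 (0.37 log units; beyond the scatter). For compound 3, the estimated value in this assay is 0.9 uM, with an expected range from 0.2 uM to 3.5 uM.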

Compound 3, concentration for half-maximal effect: 1.4 uM
Estimate against measurement, compound 3: 1.6-fold (0.19 log units) below; measured number inside the range.
By their numbers in this assay, from the lowest: compounds 2, 3 and 1 (each within the scatter of the next).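

In this assay, exchanging tert-butyl for propoxy on an aromatic carbon, para to a large group, gives a 1.5-fold lower number from compound 1 to compound 3 (0.18 log units; within the scatter), the first direct measure of a step at this position. The two groups differ in kind, since tert-butyl is built of 4 carbon atoms and propoxy of 3 carbon atoms and 1 oxygen, with propoxy bringing 1 hydrogen-bond acceptor where tert-butyl has 0, yet on this read-out compound 1 and compound 3 cannot be told apart, so at this position the read-out does not register the exchange of these two groups. No other measurement bears on this result, and it stays a bare observation on cytotoxicity in a single cell line.

This single step, between two groups of equal size by heavy-atom count, leaves open whether any group at this position can move the number beyond the scatter. An amine, a carboxylic acid or a longer chain such as hexyloxy on the same aromatic carbon would test this, and the compounds shown say nothing about how any of these would behave.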